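Amide-nitrogen variation in the shared-core series

The source may hold more compounds than are shown below. What is called first, only, known or untested is meant among the compounds shown, and "the series" means these compounds.

Compound 3 `COc1ccc2c(=O)c(/C=C/C(=O)Nc3ccccc3C)coc2c1` is one of three analogues that differ only in the group on the amide-type nitrogen. In a functional assay on A549 cells (Homo sapiens) for inhibition, read by MTT assay, with a stated time of 48 h (on this read-out higher numbers stand for weaker inhibition and lower numbers for stronger inhibition), compound 3 gives 23400 nM. Among the measured compounds shown here, compound 2 `COc1ccc(NC(=O)/C=C/c2coc3cc(OC)ccc3c2=O)cc1` gives 23000 nM in this assay, and the step of a 1.0-fold higher number from compound 2 to compound 3 (0.01 log units; within the scatter) is within the scatter, so these two numbers cannot be separated; they are the only two real numbers in the set. Compound 1 `COc1ccc2c(=O)c(/C=C/C(=O)Nc3ccc(Cl)cc3)coc2c1` reaches the limit > 100000 nM in this assay, which is a limit and not a number (the limit of > 100000 nM in this assay, at which 1 of the 3 values shown sits). The step of an at least 4.2-fold lower number from compound 1 to compound 3 (0.63 log units; beyond the scatter) is therefore at least modest, and an at least 4.3-fold lower number from compound 1 to compound 2 (0.63 log units; beyond the scatter) likewise.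

Compound 4 `COc1ccc2c(=O)c(/C=C/C(=O)NCc3ccc(F)cc3F)coc2c1` is not yet measured. It differs from compound 3 by 2,4-difluorobenzyl in place of 2-methylphenyl on an amide-type nitrogen. For the measured compounds named here, the steps that bear on this change are the two swaps on the same nitrogen: an at least 4.2-fold lower number from compound 1 to compound 3 (0.63 log units; beyond the scatter), at least modest, and a 1.0-fold higher number from compound 2 to compound 3 (0.01 log units; within the scatter), within the scatter. Passing from 2-methylphenyl to 2,4-difluorobenzyl is a larger change than either of those, and no measured pair shows what a benzyl brings on this nitrogen. The expectation is a step of a 1.1-fold higher number from compound 3 to compound 4 (0.03 log units; within the scatter) that stays within or only slightly beyond the scatter, with no direction favoured. Compound 4 is estimated at 25000 nM, with a range from 6000 nM to 100000 nM.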

Compound 4, half-maximal inhibitory concentration: 13300 nM
For compound 4 the middle estimate is 1.9-fold (0.27 log units) above the measured one, and the stated range covers the measured number.
By their numbers in this assay, from the lowest: compounds 4, 2 and 3 (each within the scatter of the next). At a limit, above all of these: compound 1.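

Compound 4 shows that this amide-type nitrogen accepts a 2,4-difluorobenzyl group without leaving the range set by the two aryl groups: in this assay, a 1.8-fold lower number from compound 3 to compound 4 (0.25 log units; within the scatter) and a 1.7-fold lower number from compound 2 to compound 4 (0.24 log units; within the scatter), and both steps stay within the scatter, so compounds 2, 3 and 4 form one group that cannot be separated, with compound 1 going against that pattern. Measured against the 4-chlorophenyl group, the same replacement gives an at least 7.5-fold lower number from compound 1 to compound 4 (0.87 log units; beyond the scatter), the largest step recorded at this position so far, which leaves the 4-chlorophenyl group as the only substituent shown that stands apart from the others. The value of compound 1 is a limit and not a number: the limit of > 100000 nM in this assay, at which 1 of the 4 values shown sits.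

The compounds shown do not separate the contribution of the benzyl group from that of its two fluorines, as neither an unsubstituted benzyl nor a 2-methylbenzyl group appears on this nitrogen. They also leave open whether a group of a different kind on the same nitrogen, such as a 2-aminoethyl chain, a carboxylic acid-bearing chain or a longer alkyl chain, would move the number beyond the scatter of this group.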